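A methoxy added to the chain of compound 1

The source may report more compounds than this note shows. Statements on the series, on what has been measured and on what is new or still open speak of the compounds shown alone.

Measured compounds:
compound 1, `CCO/C(O)=C1\C(C)=NC(C)=C([N+](=O)[O-])C1c1ccncc1`, 6460 nM
compound 2, `CCO/C(O)=C1\C(C)=NC(C)=C([N+](=O)[O-])C1c1ccccn1`, 22800 nM
compound 3, `CCO/C(O)=C1\C(C)=NC(C)=C([N+](=O)[O-])C1c1cccnc1`, 8840 nM

In a functional assay (cardiac atrium) for agonist activity, with Cavia porcellus as the target (a higher number here means that more compound is needed for the effect, a lower number that less compound is needed), compound 1 gives 6460 nM, the lowest of the three numbers. Its nearest neighbour is compound 3, and the step of a 1.4-fold higher number from compound 1 to compound 3 (0.14 log units; within the scatter) lies within the scatter, so the two cannot be ordered. Compound 2 stands furthest away, with a 3.5-fold higher number from compound 1 to compound 2 (0.55 log units; beyond the scatter), and a 2.6-fold lower number from compound 2 to compound 3 (0.41 log units; beyond the scatter) completes the picture of the three ring variants.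

Compound 4, `COCCO/C(O)=C1\C(C)=NC(C)=C([N+](=O)[O-])C1c1ccncc1`, differs from compound 1 in a different place: methoxy in place of hydrogen on a saturated chain carbon, two bonds along the chain from an oxygen on an unsaturated carbon. The ring on the saturated ring carbon, the only part that varied among the three measured compounds, is unchanged. For the measured compounds named here, none of the measured steps therefore bears on this change; each of them swaps one pyridyl for another and says nothing about the chain. There is no evidence in these three compounds for either a rise or a fall, so the account expects no step beyond the scatter in this assay, with a wider uncertainty than usual. Compound 4 is accordingly estimated at 6500 nM, between 2500 nM and 17000 nM, which means an expected step of a 1.0-fold higher number from compound 1 to compound 4 (0.00 log units; within the scatter).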

Compound 4, half-maximal effective concentration: 37700 nM
The estimate for compound 4 lay 5.8-fold (0.76 log units) below the measured number; the whole stated range lies below it.
By their numbers in this assay, from the lowest: compounds 1 and 3 (each within the scatter of the next); then compounds 2 and 4 (each within the scatter of the next).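

The chain, which stayed the same across the three pyridyl variants, proves not to be a silent part of the molecule: with the pyridin-4-yl ring held fixed, going from ethoxy to 2-methoxyethoxy gives a 5.8-fold higher number from compound 1 to compound 4 (0.77 log units; beyond the scatter) in this assay. This shows that the number in this assay responds to a change away from the ring as well as to a change of the ring itself, and that here methoxy in place of hydrogen on a saturated chain carbon, two bonds along the chain from an oxygen on an unsaturated carbon, raises the amount of compound needed for the effect. No measurement available here bears on what lies behind this rise, so it stands as an observation only.

Going by these compounds, what remains open is whether the step belongs to the methoxy itself or would also appear with another group at this place, such as a hydroxyl, an amine or a longer alkyl chain. Also open, on these data alone, is whether the same chain change would give a step of similar size on the pyridin-2-yl and pyridin-3-yl compounds, since the chain has so far been varied only on the pyridin-4-yl compound.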